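Shortening the Butyl Chain of Compound 1

A few compounds are considered here, and "the series" means these few. Any claim that something is new, unique, unknown or untested is made for them only; others in the source may bear on it.

Among the compounds with values here, compound 1 `CCCCc1ccc(COC(=O)N[C@H]2CNC2=O)cc1` was tested in an assay on HEK293 cells for inhibition of N-acylethanolamine-hydrolyzing acid amidase (Homo sapiens), read by fluorescence, with stated times of 10 min and 50 min (a higher number here means a weaker inhibitor, a lower number a stronger inhibitor), and gave 23 nM, the lowest number among the three compounds measured so far. Its nearest neighbour is compound 2 `O=C(N[C@H]1CNC1=O)OCc1ccc2c(c1)CCC2`, which in this assay gives 130 nM. Compound 3 `CC(OC(=O)N[C@H]1CNC1=O)c1ccc(C2CCCCC2)cc1` lies furthest away, with 4470 nM in this assay. Compound 4 `CCc1ccc(COC(=O)N[C@H]2CNC2=O)cc1` has not yet been measured. It differs from compound 1 in one place: hydrogen in place of ethyl on a saturated chain carbon, two bonds along the chain from an aromatic carbon, so the butyl chain becomes an ethyl chain. Within the data shown here, no pair of measured compounds shows this change on its own, so the size of the step is uncertain. Compound 4 is expected to give a somewhat higher number than compound 1, beyond the scatter. The expected step is a 4.3-fold higher number from compound 1 to compound 4 (0.64 log units; beyond the scatter). Compound 4 is estimated at about 100 nM, in a range from 30 nM to 400 nM.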

Compound 4, half-maximal inhibitory concentration: 160 nM
Compound 4: the middle estimate sits 1.6-fold (0.20 log units) below what was measured; low and high end bracket the measured number.
By their numbers in this assay, from the lowest: compound 1; then compounds 2 and 4 (each within the scatter of the next); then compound 3.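

In this assay, shortening the butyl chain to an ethyl chain gives a 7.0-fold higher number from compound 1 to compound 4 (0.84 log units; beyond the scatter) and so makes clear that inhibition depends on the length of this chain. Within the data shown here, this is the first single change that can be read on its own, as the earlier compounds offered no such pair. No measurement here explains the size of this step.

On these data alone, how a propyl chain or a chain longer than butyl, such as pentyl or hexyl, would compare remains open. So does the effect of placing an amine or a carboxylic acid on this chain.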